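Adding a Second Chloro Group on the Aryl Ring

A few compounds are considered here, and "the series" means these few. Any claim that something is new, unique, unknown or untested is made for them only; others in the source may bear on it.

The compounds measured so far:
compound 1, `CC(C)(C)c1ccc(C(CCN2CCN(c3ccccc3)CC2)OC(N)=O)cc1`, 62% in a functional assay on the whole organism for inhibition, with Mus musculus as the target, in the writhing test, with a stated time of 1 h, at a dose of 10 mg/kg by the oral route; a lower number here means less inhibition, a higher number more inhibition at the dose given (going by the name of the read-out)
compound 2, `COc1ccc(N2CCN(CCC(OC(N)=O)c3ccc(Cl)cc3)CC2)cc1`, 51% in this assay
compound 3, `NC(=O)OC(CCN1CCN(c2ccc(Cl)c(C(F)(F)F)c2)CC1)c1ccccc1`, 52% in this assay

All three share the same shape: a carbamate group on a carbon that also carries an aromatic ring, linked through a short chain to a piperazine bearing a second aromatic ring. Compound 2 stands at the lower end of the numbers seen. Its value and that of compound 3 lie within the usual scatter of each other, so nothing separates them. Compound 1 gives a number higher than that of compound 2 by a gap that lies beyond the scatter.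

Compound 4, `COc1ccc(N2CCN(CCC(OC(N)=O)c3ccc(Cl)cc3Cl)CC2)cc1`, has not yet been measured. It differs from compound 2 in one place: chloro in place of hydrogen on an aromatic carbon. Among the compounds with values here, no pair of measured compounds differs in just this way, so there is no direct precedent for the size or direction of the step. The expectation is that the step from compound 2 to compound 4 in this assay is small, a number 1 percentage points higher from compound 2 to compound 4 (within the scatter), and most likely none beyond the scatter. On that basis compound 4 is expected to give about 52%, within a range from 38% to 66%.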

Compound 4, a percentage reported as inhibition, in the whole organism at one dose (the size of the read-out at that dose, not a potency): 16%
Beside the measured number, compound 4's estimate is 36 percentage points above it, outside the stated range (below it).
By their numbers in this assay, from the lowest: compound 4; then compounds 2, 3 and 1 (each within the scatter of the next, the first and the last beyond it).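

Going from 4-chlorophenyl to 2,4-dichlorophenyl gives a number 35 percentage points lower from compound 2 to compound 4 (beyond the scatter) in this assay, so one chloro in place of hydrogen on this aromatic carbon, ortho to a large group, is enough to change the result by well beyond the scatter. Within the data shown here, the earlier compounds differ from one another in more than one place, so none of them could show what a single position contributes; this pair is the first to do so, and it shows that this carbon is highly sensitive to change in this test. The read-out is a size of effect at one dose rather than a potency, and no measurement at hand accounts for the drop.

The compounds shown leave open whether the loss belongs to chloro itself or would also follow from a smaller or different group on the same carbon, such as fluoro, methyl or an amine. They also leave open whether adding chloro at the matching place on the ring of compound 1 or compound 3 would bring a similar step.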